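A few compounds are considered here, and "the series" means these few. Any claim that something is new, unique, unknown or untested is made for them only; others in the source may bear on it.

In a functional assay on A549 cells (Homo sapiens) for inhibition, read by colorimetric assay and MTT assay, with a stated time of 72 h (on this read-out lower numbers stand for stronger inhibition and higher numbers for weaker inhibition), compound 1 `C=CCCCCOc1ncc(-c2cc(Cl)ccc2OC)n1C` gives 34000 nM. Compound 2 `C=CCCCCOc1ncc(I)n1C` gives only a limit of the assay, > 100000 nM, and not an exact number. Compound 3 `C=CCCCCOc1nccn1C` differs from compound 2 in one place: hydrogen in place of iodo on an aromatic carbon, with hydrogen in place of iodo on an aromatic carbon. For the measured compounds named here, no measured pair of compounds shows the effect of this swap alone. The expected change in this assay is therefore none beyond the scatter, with no clear gain in strength. Compound 3 is expected to give about 120000 nM, with an estimated range of 50000 nM to 300000 nM.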

Compound 3, half-maximal inhibitory concentration: > 100000 nM
Compound 3: only a limit was reported; the forecaster's own chance of this, stated with the estimate: 70%; the middle value does not contradict the limit.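

No step can be read from compound 2 to compound 3, because each gives only a limit and not an exact number: the limit of > 100000 nM in this assay, at which 2 of the 3 values shown sit.

The compounds shown leave open whether hydrogen in place of iodo on an aromatic carbon changes inhibition at all.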